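The compounds below may be only part of what the source reports. "The series", "measured", "known", "first", "only" and "open" are said of these compounds alone.

Measured compounds:
compound 1 `CCc1cccc(NC(=O)CN2CCC(c3cccc[n+]3[O-])CC2)c1` — 95 nM
compound 2 `Cc1cc(C(=O)NCN2CCC(c3cccc[n+]3[O-])CC2)ccc1F` — 50 nM
compound 3 `CC(C)Oc1cccc(NC(=O)CN2CCC(c3cccc[n+]3[O-])CC2)c1` — 555 nM

In a functional assay on HEK293 cells for agonist activity at D(4) dopamine receptor (Homo sapiens), read by FLIPR (on this read-out higher numbers stand for an effect only at larger amounts of compound and lower numbers for an effect already at smaller amounts), compound 2 gives the lowest of the three numbers; compound 1 lies within the scatter of it, while compound 3 sits beyond the scatter above it. Compound 4 `N#Cc1cccc(C(=O)NCN2CCC(c3cccc[n+]3[O-])CC2)c1` differs from compound 2 by 3-cyanophenyl in place of 4-fluoro-3-methylphenyl on a carbonyl carbon. Within the data shown here, no measured step changes a group on a carbonyl carbon whose other neighbours are an amide-type nitrogen; the only step available, a 5.8-fold higher number from compound 1 to compound 3 (0.77 log units; beyond the scatter), concerns a substituent on an aromatic carbon of a different part of the shared core, and shows that exchanging one ring substituent for another can shift the read-out modestly. For compound 4 a modest rise is expected, a 2.4-fold higher number from compound 2 to compound 4 (0.38 log units; beyond the scatter), with the estimate for compound 4 at 120 nM in this assay, within the range 30 nM to 500 nM.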

Compound 4, half-maximal effective concentration: 840 nM
Beside the measured number, compound 4's estimate is 7.0-fold (0.85 log units) below it; the measured number lies above the stated range.
By their numbers in this assay, from the lowest: compounds 2 and 1 (each within the scatter of the next); then compounds 3 and 4 (each within the scatter of the next).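

In this assay, this is the first change shown on a carbonyl carbon whose other neighbours are an amide-type nitrogen, and 3-cyanophenyl in place of 4-fluoro-3-methylphenyl gives a large step, a 17-fold higher number from compound 2 to compound 4 (1.23 log units; beyond the scatter). The two groups have the same heavy-atom count and the same kind of aromatic ring, so these shared counts do not keep the read-out steady. Nothing at hand accounts for this step.

The compounds shown do not separate the arrival of the nitrile from the loss of the fluorine and the methyl. On these data alone, how 3-methylphenyl, 4-fluorophenyl or an aminophenyl would read at this place remains open.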